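Replacing the Nitrophenyl Ketone with a Thiophene Ring

A few compounds are considered here, and "the series" means these few. Any claim that something is new, unique, unknown or untested is made for them only; others in the source may bear on it.

Among the measured compounds shown here, compound 2 `COc1ccc(-c2cc3ccccc3nc2/C=C/C(=O)c2ccc([N+](=O)[O-])cc2)cc1` holds the lowest of the two numbers so far recorded in a functional assay on MDA-MB-231 cells (Homo sapiens) for antiproliferative activity, read by XTT assay, with a stated time of 72 h (a lower number here means a stronger inhibitor, a higher number a weaker inhibitor), where compound 2 gives 840 nM. For the measured compounds named here, its nearest measured neighbour is compound 1 `COc1ccc(-c2cc3ccccc3nc2/C=C/C(=O)c2ccc(N)cc2)cc1`, which in this assay gives 7510 nM; the one step between them, an 8.9-fold lower number from compound 1 to compound 2 (0.95 log units; beyond the scatter), comes from nitro in place of amino on an aromatic carbon. Compound 3 `COc1ccc(-c2cc3ccccc3nc2/C=C/C(=O)c2cccs2)cc1` is not yet measured. It differs from compound 2 by thiophen-2-yl in place of 4-nitrophenyl on a carbonyl carbon. Going by the values given here, only the step from compound 1 to compound 2 touches the group on that carbonyl carbon, and it was modest; no measured step shows a thiophene there, so the direction stays uncertain. Compound 3 is estimated to give 2000 nM, with a range from 500 nM to 8000 nM, a modest weakening expected as a 2.4-fold higher number from compound 2 to compound 3 (0.38 log units; beyond the scatter).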

Compound 3, half-maximal inhibitory concentration: 410 nM
Compound 3: the middle estimate sits 4.9-fold (0.69 log units) above what was measured, and the stated range ends above it.
By their numbers in this assay, from the lowest: compound 3; then compound 2; then compound 1.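

In this assay, the carbonyl carbon tolerates more than a substituted six-membered aromatic ring of carbon only: thiophen-2-yl, a five-membered aromatic ring with 1 hetero atom and 5 heavy atoms in place of 9, gives a 2.0-fold lower number from compound 2 to compound 3 (0.31 log units; beyond the scatter) and so keeps the activity without the nitro group. Set against the 4-aminophenyl group, the same thiophen-2-yl gives an 18-fold lower number from compound 1 to compound 3 (1.26 log units; beyond the scatter), the largest step among the three compounds at this position. No measurement available here accounts for either step.

The compounds shown do not tell whether the sulfur atom, the five-membered ring or the loss of the nitro group carries the change. A furan-2-yl ring, a thiophen-3-yl ring or an unsubstituted phenyl ring on the same carbonyl carbon would help to separate these possibilities.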